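A few compounds are considered here, and "the series" means these few. Any claim that something is new, unique, unknown or untested is made for them only; others in the source may bear on it.

Measured compounds:
compound 1 `COc1ccc2nc(Nc3ccnc(Nc4ccc(S(N)(=O)=O)cc4)n3)sc2c1`: 1730 nM
compound 2 `Cc1cnc(Nc2ccc(Cl)cc2)nc1Nc1nc2ccccc2s1`: > 50000 nM
compound 3 `CS(=O)(=O)c1ccc(Nc2ncc(F)c(Nc3nc4ccccc4s3)n2)cc1`: 3170 nM

Of the compounds shown here, three have been tested in a functional assay on HeLa cells (Homo sapiens) for antiproliferative activity, read by MTT assay, with a stated time of 48 h; a higher number here means a weaker inhibitor, a lower number a stronger inhibitor. Compound 1 gives 1730 nM and compound 3 gives 3170 nM. For compound 2 the result is only a limit, > 50000 nM; this is the limit of > 50000 nM in this assay, at which 1 of the 3 values shown sits. Compound 2 therefore stands at the weak end of the numbers shown, without a number of its own. Compound 4 `Cc1cnc(Nc2ccc([N+](=O)[O-])cc2)nc1Nc1nc2ccccc2s1` differs from compound 2 by a single change: nitro in place of chloro on an aromatic carbon. No measured step of this kind exists among these compounds, so the size of the change is uncertain; a move toward stronger inhibition seems possible, yet a second limit is also plausible. Compound 4 is expected at about 25000 nM, within 4000 nM to 50000 nM. That amounts to an expected step of an at least 2.0-fold lower number from compound 2 to compound 4 (0.30 log units; that floor lies within the scatter).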

Compound 4, half-maximal inhibitory concentration: 34300 nM
Beside the measured number, compound 4's estimate is 1.4-fold (0.14 log units) below it, and the stated range covers the measured number.
By their numbers in this assay, from the lowest: compounds 1 and 3 (each within the scatter of the next); then compound 4. At a limit, above all of these: compound 2.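

In this assay, the change from 4-chlorophenyl to 4-nitrophenyl gives this position its first measured number, with an at least 1.4-fold lower number from compound 2 to compound 4 (0.16 log units; that floor lies within the scatter). A gain beyond the scatter cannot be claimed from this step, since it gives only a floor. Compound 2 remains a limit, not a number: the limit of > 50000 nM in this assay, at which 1 of the 4 values shown sits.

From the compounds shown here alone, what an amine or a carboxylic acid in this place on the aromatic ring would give remains open. So does whether the nitro group itself matters, or only the loss of chloro.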